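This account rests on a few compounds, and the source may have more. Where it says the series, first, only, none or still open, it means among the compounds named here.

Measured so far in an assay on isolated protein for inhibition of leukotriene C4 synthase (Homo sapiens), read by LC-MS, with stated times of 45 min and 20 min; on this read-out higher numbers stand for weaker inhibition and lower numbers for stronger inhibition:
compound 1 `CCCN(c1cnc(C(=O)[C@H]2C[C@@H]2C(=O)O)c(OC)c1)c1ccc(F)c2ccccc12`, 7.09 nM
compound 2 `CCN(c1cnc(C(=O)[C@H]2C[C@@H]2C(=O)O)c(OC)c1)c1ccc(F)c2ccccc12`, 16.8 nM
compound 3 `CCCN(c1cccc(C(F)(F)F)c1)c1cnc(C(=O)[C@H]2C[C@@H]2C(=O)O)c(OC)c1`, 58.4 nM

Among these three, compound 3 has the highest number in this assay, above compound 2 and well above compound 1. Compound 4 `CCN(c1cccc(C(F)(F)F)c1)c1cnc(C(=O)[C@H]2C[C@@H]2C(=O)O)c(OC)c1` is not yet measured. It differs from compound 3 by hydrogen in place of methyl on a saturated chain carbon, two bonds along the chain from a nitrogen on an aromatic ring. The same change, in the same place, separates compound 1 from compound 2: hydrogen in place of methyl on a saturated chain carbon, two bonds along the chain from a nitrogen on an aromatic ring, and there it made a 2.4-fold higher number from compound 1 to compound 2 (0.37 log units; beyond the scatter). The difference between the core of compound 1 and the core of compound 3 is not broken down here. Within the data shown here, because the only comparable step is a 2.4-fold higher number from compound 1 to compound 2 (0.37 log units; beyond the scatter), a step of similar size is expected, namely a 2.4-fold higher number from compound 3 to compound 4 (0.38 log units; beyond the scatter). Compound 4 is therefore estimated at 140 nM, most likely between 60 nM and 330 nM.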

Compound 4, half-maximal inhibitory concentration in the leukotriene C4 synthase assay: 113 nM
Estimate against measurement, compound 4: 1.2-fold (0.09 log units) above; low and high end bracket the measured number.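

In the leukotriene C4 synthase assay the change from propyl to ethyl gives a 1.9-fold higher number from compound 3 to compound 4 (0.29 log units; within the scatter), a step that taken alone cannot be told from scatter. Set beside the earlier step, it shows no detectable difference in size between the two cores, so the change appears to carry over from one to the other: the same change on two cores in the leukotriene C4 synthase assay, a 2.4-fold higher number (0.37 log units; beyond the scatter) from compound 1 to compound 2 and a 1.9-fold higher number (0.29 log units; within the scatter) from compound 3 to compound 4, 1.2-fold (0.09 log units) apart, within the scatter of two such steps. Among these compounds, this rests on only two pairs and does not show that the step would hold on other cores, though in a physicochemical assay for lipophilicity, read by LC-MS, in phosphate buffer, measured as octanol-water partition, at pH 7.4 (on this read-out higher numbers stand for higher lipophilicity and lower numbers for lower lipophilicity), compound 3 gives 1.2 and compound 4 gives 0.7, so the same pair also differs: the measured distribution coefficient of compound 3, 1.2, and of compound 4, 0.7, a number 0.50 log units lower (beyond the scatter).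

On these data alone, what a longer chain such as butyl, or a chain ending in an amine, would do in place of propyl stays open. As far as these compounds go, it is also open whether the step would keep its size on a third core.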